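A few compounds are considered here, and "the series" means these few. Any claim that something is new, unique, unknown or untested is made for them only; others in the source may bear on it.

In a functional assay on K562 cells (Homo sapiens) for inhibition, read by trypan blue exclusion, with a stated time of 72 h (a lower number here means a stronger inhibitor, a higher number a weaker inhibitor), compound 1 (`COc1ccc(Nc2ncc3cc(S(=O)(=O)c4ccc(C)cc4)c(=O)n(C)c3n2)cc1`) gives 75000 nM as its number, compound 2 (`COc1ccc(S(=O)(=O)c2cc3cnc(Nc4cccc5[nH]ccc45)nc3n(C)c2=O)cc1`) gives 5000 nM and compound 3 (`Cc1ccc(S(=O)(=O)c2cc3cnc(Nc4cccc5cccnc45)nc3n(C)c2=O)cc1`) gives 10000 nM on the same scale. Compound 3 therefore sits within the scatter of compound 2. Its gap to the remaining compound is a 7.5-fold lower number from compound 1 to compound 3 (0.88 log units; beyond the scatter) and came with quinolin-8-yl in place of 4-methoxyphenyl on a nitrogen on an aromatic ring. Compound 4 (`Cc1ccc(S(=O)(=O)c2cc3cnc(Nc4cccc5[nH]ccc45)nc3n(C)c2=O)cc1`) follows from compound 3 by 1H-indol-4-yl in place of quinolin-8-yl on a nitrogen on an aromatic ring and this puts 1H-indol-4-yl in place of quinolin-8-yl at that same kind of nitrogen. Among the compounds with values here, the one measured step shows that this place can shift the number, but it starts from a different group. Compound 2 already carries 1H-indol-4-yl there with 5000 nM as its number, although it differs from compound 4 elsewhere. The expected change is a 2.0-fold lower number from compound 3 to compound 4 (0.30 log units; within the scatter) in this assay as a small move toward a lower number and not clearly beyond the scatter. For compound 4 the estimated value is 5000 nM with an expected range from 1500 nM to 15000 nM in this measurement.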

Compound 4, half-maximal inhibitory concentration: 5000 nM
For compound 4 middle estimate and measured number coincide at the digits printed; measured number inside the range.
By their numbers in this assay, from the lowest: compounds 2, 4 and 3 (each within the scatter of the next); then compound 1.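

In this assay the exchange on the nitrogen gives a 2.0-fold lower number from compound 3 to compound 4 (0.30 log units; within the scatter) so at this place 1H-indol-4-yl and quinolin-8-yl cannot be told apart, although they differ in ring size and in their hydrogen-bond donor and acceptor counts. Against 4-methoxyphenyl at the same nitrogen, 1H-indol-4-yl gives a 15-fold lower number from compound 1 to compound 4 (1.18 log units; beyond the scatter) which shows that this group, like quinolin-8-yl, stands clearly apart from 4-methoxyphenyl. A second place can now be read as well: methyl in place of methoxy on an aromatic carbon gives no change at the digits printed from compound 2 to compound 4 (within the scatter) with 1H-indol-4-yl on the nitrogen. Nothing measured here accounts for these steps. The compounds shown leave open whether an amine or a carboxylic acid on that aromatic carbon would shift the number, and whether methyl and methoxy also read alike with quinolin-8-yl on the nitrogen.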